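The source may hold more compounds than are shown below. What is called first, only, known or untested is meant among the compounds shown, and "the series" means these compounds.

Compound 1, `CN(Cc1ccccc1)C(=S)SCC1=CC(=O)OC1`. In a functional assay on HeLa cells (Homo sapiens) for antiproliferative activity, read by MTT assay, with a stated time of 72 h (a lower number here means a stronger inhibitor, a higher number a weaker inhibitor), compound 1 gives > 50 ug/mL, a limit of the assay rather than a number.
Compound 2, `CN(C)C(=S)SCC1=CC(=O)OC1`. In this assay compound 2 gives > 50 ug/mL, again a limit.
Compound 3, `O=C1CC2(CO1)CSC(=S)N2Cc1ccccc1`. In this assay compound 3 gives > 50 ug/mL, also a limit.

Compound 2 thus stands only at a limit in this assay, and the two other values shown sit at the same limit (the limit of > 50 ug/mL in this assay, at which 3 of the 3 values shown sit). Within the data shown here, the one step that connects two measured compounds, a step that the two limits leave unreadable from compound 1 to compound 2, cannot be read, since both of its ends are limits. Compound 3 and compound 2 are not linked by a single step; their values show nothing beyond the shared limit.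

Compound 4, `O=C1C=C(CSC(=S)N2CCCC2)CO1`, is the next member to be measured. It differs from compound 2 by pyrrolidin-1-yl in place of dimethylamino on a thiocarbonyl carbon. Among the measured compounds shown here, the only measured step that alters the group on the thiocarbonyl carbon is a step that the two limits leave unreadable from compound 1 to compound 2, and it is unreadable, so neither size nor direction can be taken from it. For compound 4 the expected step that the limit leaves unreadable from compound 2 to compound 4 is accordingly set at none beyond the scatter, with a limit again the most likely outcome. Compound 4 is estimated at 60 ug/mL in this assay, within 25 ug/mL to 150 ug/mL.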

Compound 4, half-maximal inhibitory concentration: > 50 ug/mL
Compound 4 was reported as a limit (the forecaster's own chance of this, stated with the estimate: 80%); the middle value is on the limit's open side.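

Among these compounds, compound 4, like compound 2, stands at a limit, so the step between them cannot be read and no new step emerges: the limit of > 50 ug/mL in this assay, at which 4 of the 4 values shown sit.
The compounds shown leave open whether any group on the thiocarbonyl carbon gives a readable value in this assay at all.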